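The source may report more compounds than this note shows. Statements on the series, on what has been measured and on what is new or still open speak of the compounds shown alone.

Compound 1 `CN(C)c1cc2[nH]c(C3CCCCC3)nc2cc1NC(=O)c1ccco1`: in an ADME assay on Vero cells (Chlorocebus sabaeus) for cytotoxicity, read by resazurin assay, with a stated time of 3 days (a higher number here means a weaker inhibitor, a lower number a stronger inhibitor), compound 1 gives > 100 ug/mL, a limit of the assay.
Compound 2 `CCN(CC)c1cc2[nH]c(C3CCCCC3)nc2cc1NC(=O)c1ccc(OC(F)(F)F)cc1`: in this assay compound 2 gives > 100 ug/mL, also a limit.
Compound 3 `CN(C)c1cc2[nH]c(C3CCCCC3)nc2cc1NC(=O)c1ccc(OC(F)(F)F)cc1`: in this assay compound 3 gives > 100 ug/mL, again a limit.

Compound 2 thus stands at the upper edge of what this assay reports, as do both other measured compounds. Among the compounds with values here, the only measured one-place step, a step that the two limits leave unreadable from compound 2 to compound 3, is unreadable, so its size is unknown.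

Compound 4 `CCOCCOC(=O)Nc1cc2nc(C3CCCCC3)[nH]c2cc1N(CC)CC` differs from compound 2 by 2-ethoxyethoxy in place of 4-(trifluoromethoxy)phenyl on a carbonyl carbon. Within the data shown here, no measured step bears directly on this change. Among the measured compounds shown here, the one fact that can guide an expectation is the limit of > 100 ug/mL in this assay, at which 3 of the 3 values shown sit, so a step beyond the scatter, in either direction, is not expected here. The expected step is a number no higher from compound 2 to compound 4 (the limit leaves the size open). Compound 4 is therefore estimated at 100 ug/mL, in a range from 30 ug/mL to 300 ug/mL, most probably reported as a limit once more.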

Compound 4, half-maximal inhibitory concentration: > 100 ug/mL
Compound 4 gave a limit, no number; the forecaster's own chance of this, stated with the estimate: 80%; the middle value lies on the limit itself.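

Compound 2 and compound 4 both give limits in this assay, and the step between them cannot be read. The compounds shown leave open where the true value of any of them lies, and whether exchanging these groups changes the read-out at all.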